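Moving Two Methoxy Groups Around a Phenyl Ring

The source may report more compounds than this note shows. Statements on the series, on what has been measured and on what is new or still open speak of the compounds shown alone.

compound 1, `COc1ccc(/C=C/C(=O)Nc2cc3c(Nc4ccc(F)c(Cl)c4)ncnc3cc2OC)c(OC)c1`: 36600 nM
compound 2, `COc1ccc(OC)c(/C=C/C(=O)Nc2cc3c(Nc4ccc(F)c(Cl)c4)ncnc3cc2O[C@H]2CCOC2)c1`: 36300 nM
compound 3, `COc1cc(/C=C/C(=O)Nc2cc3c(Nc4ccc(F)c(Cl)c4)ncnc3cc2OC)cc(OC)c1`: 38500 nM

Of the compounds shown here, three have been measured in a functional assay on MCF7 cells (Homo sapiens) for cytotoxicity, read by MTT assay, with a stated time of 72 h; on this read-out lower numbers stand for stronger inhibition and higher numbers for weaker inhibition. Compound 3 sits within one tight cluster with the other two: its gap to compound 1 and its gap to compound 2 both fall within the scatter, so none of the three can be called more or less potent than another.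

Compound 4, `COc1ccc(OC)c(/C=C/C(=O)Nc2cc3c(Nc4ccc(F)c(Cl)c4)ncnc3cc2OC)c1`, differs from compound 3 only at the aryl ring of the acrylamide arm: 2,5-dimethoxyphenyl in place of 3,5-dimethoxyphenyl on a double-bonded chain carbon bound to a double-bonded chain carbon. For the measured compounds named here, one measured step bears on this kind of change. Moving the two methoxy groups from the 2,4-pattern to the 3,5-pattern gave a 1.1-fold higher number from compound 1 to compound 3 (0.02 log units; within the scatter), a step of no consequence. Compound 2, which already carries the 2,5-dimethoxyphenyl but a different ether on the shared core, gives a value indistinguishable from compound 1 and compound 3. The step from compound 3 to compound 4 is therefore expected to be a 1.0-fold lower number from compound 3 to compound 4 (0.02 log units; within the scatter), within the scatter. Compound 4 is estimated at 37000 nM, with a range from 18000 nM to 75000 nM.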

Compound 4, half-maximal inhibitory concentration: 34300 nM
Compound 4: the middle estimate sits 1.1-fold (0.03 log units) above what was measured; the measured number falls inside the stated range.
By their numbers in this assay, from the lowest: compounds 4, 2, 1 and 3 (each within the scatter of the next).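

In this assay, 2,5-dimethoxyphenyl on a double-bonded chain carbon bound to a double-bonded chain carbon gives a 1.1-fold lower number from compound 3 to compound 4 (0.05 log units; within the scatter) and, measured against the 2,4-dimethoxyphenyl, a 1.1-fold lower number from compound 1 to compound 4 (0.03 log units; within the scatter) and so all three methoxy patterns can now be compared directly on one methyl ether, and none can be told apart. For the compounds shown here, the change at the other place, methyl in place of oxolan-3-yl on an oxygen on an aromatic ring, gives a 1.1-fold lower number from compound 2 to compound 4 (0.02 log units; within the scatter) and thus isolates that ether for the first time, and it too cannot be told from no change. Nothing available offers a reason for this flat picture.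

From the compounds shown here alone, what an amine or a carboxylic acid on this aryl ring would do remains open. So does whether the oxolan-3-yl ether would read the same alongside the other two methoxy patterns.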